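Hydroxy in place of iodo on the shared core

A few compounds are considered here, and "the series" means these few. Any claim that something is new, unique, unknown or untested is made for them only; others in the source may bear on it.

Compound 1 `Nc1nc2c(nc(Cl)n2COCCO)c(=O)[nH]1`. In a functional assay on L1210 cells (Mus musculus) for inhibition (a lower number here means a stronger inhibitor, a higher number a weaker inhibitor), compound 1 gives > 1000 ug/mL, which is a limit of the assay and not a number.
Compound 2 `Nc1nc2c(nc(I)n2COCCO)c(=O)[nH]1`. In this assay compound 2 gives > 1000 ug/mL, again a limit of the assay rather than a number.

On the numbers shown, compound 2 stands only at a limit; the single other value shown is also a limit, so compound 2 cannot be placed relative to compound 1. Among the compounds with values here, the one measured step, a step that the two limits leave unreadable from compound 1 to compound 2, is therefore of unreadable size, because of the limit of > 1000 ug/mL in this assay, at which 2 of the 2 values shown sit.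

Compound 3 `Nc1nc2c(nc(O)n2COCCO)c(=O)[nH]1` is unmeasured. It differs from compound 2 as follows: hydroxy in place of iodo on an aromatic carbon.

Within the data shown here, the only step that bears on this change is the unreadable one, so it gives no direction and no size. With both measured values sitting at the limit, the expectation for compound 3 rests on that limit alone. Compound 3 is estimated to give 1000 ug/mL in this assay, with a range from 300 ug/mL to 3000 ug/mL, most likely again reported as a limit. The step this estimate implies is a number no higher from compound 2 to compound 3 (the limit leaves the size open), expected to lie within the scatter.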

Compound 3, concentration for 50% inhibition: > 500 ug/mL
Compound 3 gave a limit, no number; the forecaster's own chance of this, stated with the estimate: 85%; the middle value lies beyond the limit too.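

In this assay compound 3 gives > 500 ug/mL, again a limit of the assay and not a number. Within the data shown here, no step among compound 1, compound 2 and compound 3 can be read. The compounds shown leave open whether chloro, iodo or hydroxy on this aromatic carbon of the shared core makes any difference to inhibition in this assay.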